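Adding Cyclohexyl to a Weak Inhibitor

This account rests on a few compounds, and the source may have more. Where it says the series, first, only, none or still open, it means among the compounds named here.

Measured in a functional assay on DU-145 cells (Homo sapiens) for inhibition, read by trypan blue exclusion, with a stated time of 72 h (a higher number here means a weaker inhibitor, a lower number a stronger inhibitor), so far
compound 1 `O=c1[nH]c2nc(Nc3ccc4[nH]ccc4c3)ncc2cc1S(=O)(=O)c1ccc(F)cc1F` gives 15000 nM
compound 2 `Cn1c(=O)c(S(=O)(=O)c2ccc(F)cc2)cc2cnc(Nc3cnc4[nH]ccc4c3)nc21` gives 500 nM

Compound 1 gives 15000 nM as the higher of these two numbers, so it is the weaker inhibitor, and the gap to compound 2 lies beyond the usual scatter. Compound 3 `O=c1c(S(=O)(=O)c2ccc(F)cc2F)cc2cnc(Nc3ccc4[nH]ccc4c3)nc2n1C1CCCCC1` has cyclohexyl in place of hydrogen on an aromatic nitrogen, the change cyclohexyl in place of hydrogen on an aromatic nitrogen made to compound 1. For the measured compounds named here, no measured pair shows this change alone. Going by the values given here, compound 2 differs in other places too, but its ring nitrogen bears methyl and compound 2 gives 500 nM in this assay as the only guide. The step of a 38-fold lower number from compound 1 to compound 3 (1.57 log units; beyond the scatter) is therefore expected to be a drop well beyond the scatter. Compound 3 is estimated at 400 nM with a likely range from 60 nM to 3000 nM for now.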

Compound 3, half-maximal inhibitory concentration: 10000 nM
For compound 3 the middle estimate is 25-fold (1.40 log units) below the measured one; measured number outside the range, above it.
By their numbers in this assay, from the lowest: compound 2; then compounds 3 and 1 (each within the scatter of the next).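

In this assay, cyclohexyl in place of hydrogen on the aromatic nitrogen gives a 1.5-fold lower number from compound 1 to compound 3 (0.18 log units; within the scatter). This position therefore carries a group of this size with no difference beyond the scatter, and on the core of compound 1 this change alone leaves a weak inhibitor weak. Open, going by these compounds, is whether a chain ending in an amine or a carboxylic acid on this same nitrogen would give a number beyond the scatter from that of compound 1. No measurement shown gives a reason for this result.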